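A few compounds are considered here, and "the series" means these few. Any claim that something is new, unique, unknown or untested is made for them only; others in the source may bear on it.

Compound 1 `CN(C)[C@@H]1CCN(c2cccc3c2C[C@H](CN(C)[C@H]2CCCc4cccnc42)NC3)C1` gives 10.4 nM in a functional assay on CCRF-CEM cells for antagonist activity at C-X-C chemokine receptor type 4 (Homo sapiens), read by calcium flux, with stated times of 25 min and 90 s; on this read-out lower numbers stand for stronger inhibition and higher numbers for weaker inhibition; compound 2 `CN(C)C1CCN(c2cccc3c2C[C@H](CN(C)[C@H]2CCCc4cccnc42)NC3)CC1` gives 35.9 nM.

Within the data shown here, compound 2 stands at the higher of the two numbers, the single recorded step being a 3.5-fold higher number from compound 1 to compound 2 (0.54 log units; beyond the scatter), a modest rise. Compound 3 `CN1CC[C@H]2CN(c3cccc4c3C[C@H](CN(C)[C@H]3CCCc5cccnc53)NC4)C[C@H]21` differs from compound 2 by a group of 9 heavy atoms (7 carbon, 2 nitrogen; 2 five-membered non-aromatic rings with 1 hetero atom each) in place of a group of 9 heavy atoms (7 carbon, 2 nitrogen; one six-membered non-aromatic ring with 1 hetero atom), on an aromatic carbon. Among the measured compounds shown here, the only step that bears on this is that rise from a five-membered to a six-membered non-aromatic ring; compound 3 returns to five-membered rings, so a drop of roughly that size is expected. Compound 3 is therefore estimated at 15 nM (range 5 nM to 50 nM), an expected 2.4-fold lower number from compound 2 to compound 3 (0.38 log units; beyond the scatter).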

Compound 3, half-maximal inhibitory concentration: 11.4 nM
Estimate against measurement, compound 3: 1.3-fold (0.12 log units) above; the measured number falls inside the stated range.
By their numbers in this assay, from the lowest: compounds 1 and 3 (each within the scatter of the next); then compound 2.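

Replacing the 4-(dimethylamino)piperidin-1-yl group with the group of 2 five-membered non-aromatic rings gives a clear change at this aromatic carbon (a 3.1-fold lower number from compound 2 to compound 3 (0.50 log units; beyond the scatter)). Compared with the single five-membered ring of compound 1, the same group shows no real difference (a 1.1-fold higher number from compound 1 to compound 3 (0.04 log units; within the scatter)), so among these three compounds only the six-membered ring of compound 2 stands apart. No available evidence explains this result.

The compounds shown leave open how a smaller azetidine ring or a larger azepane ring would read at this position. They also leave open whether a primary amine could replace the dimethylamino group.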